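Fluorine on the coumarin-like ring: tolerated dose in liver cells

This account rests on a few compounds, and the source may have more. Where it says the series, first, only, none or still open, it means among the compounds named here.

Four related compounds are compared in a functional assay on Huh-5-2 cells (Homo sapiens) for cytotoxicity, read by microscopy; a higher number here means that more compound is tolerated, a lower number that less compound is tolerated. Compound 1 `CC(=O)OC[C@H]1O[C@@H](n2c(SCc3cc4ccccc4oc3=O)nc3cncnc32)[C@H](OC(C)=O)[C@@H]1OC(C)=O` gives 39000 nM. Compound 2 `CC(=O)OC[C@H]1O[C@@H](n2c(SCc3cc4cc(F)ccc4oc3=O)nc3cncnc32)[C@H](OC(C)=O)[C@@H]1OC(C)=O` gives 7600 nM. Within the data shown here, the single change between them is fluoro in place of hydrogen on an aromatic carbon, and it produced a 5.1-fold lower number from compound 1 to compound 2 (0.71 log units; beyond the scatter), so compound 2 is tolerated at a clearly lower concentration.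

Compound 3 `O=c1oc2ccccc2cc1CSc1nc2cncnc2n1[C@@H]1O[C@H](CO)[C@@H](O)[C@H]1O` has a different core; the difference between the two cores is not broken down here. In this assay compound 3 gives 50000 nM, which sits within the scatter of compound 1 and is the highest of the three numbers.

Compound 4 `O=c1oc2ccc(F)cc2cc1CSc1nc2cncnc2n1[C@@H]1O[C@H](CO)[C@@H](O)[C@H]1O` has not yet been measured. It differs from compound 3 by fluoro in place of hydrogen on an aromatic carbon, the same change as between compound 1 and compound 2. Because a 5.1-fold lower number from compound 1 to compound 2 (0.71 log units; beyond the scatter) was seen for that change, a similar step is expected here: the estimated step is a 5.0-fold lower number from compound 3 to compound 4 (0.70 log units; beyond the scatter). For compound 4 the expected value in this assay is 10000 nM, with a likely range from 4000 nM to 30000 nM. This rests on a single earlier example, so the range is kept wide.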

Compound 4, half-maximal cytotoxic concentration: 36000 nM
For compound 4 the middle estimate is 3.6-fold (0.56 log units) below the measured one; the measured number lies above the stated range.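

In this assay, putting fluoro in place of hydrogen on the core of compound 3 gave a 1.4-fold lower number from compound 3 to compound 4 (0.14 log units; within the scatter), a step too small to tell apart from the ordinary spread of repeated measurements. Set beside the earlier step, this shows that the size of the step did not carry over from one core to the other: the same change on two cores in this assay, a 5.1-fold lower number (0.71 log units; beyond the scatter) from compound 1 to compound 2 and a 1.4-fold lower number (0.14 log units; within the scatter) from compound 3 to compound 4, 3.7-fold (0.57 log units) apart, beyond the scatter of two such steps. Among these compounds, the clear drop seen on the core of compound 1 therefore cannot be assumed on another core, but with only one pair per core, these results do not show why the two cores differ or what the change would do on a third core.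

From the compounds shown here alone, it remains open whether another group at this same place, such as chloro, methoxy or an amine, would also give different steps on the two cores. Also open is which part of the difference between the cores goes with the gap, as each compound shown carries one core or the other whole.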